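Swapping fluoro for methoxy on a chalcone-type inhibitor

The source may report more compounds than this note shows. Statements on the series, on what has been measured and on what is new or still open speak of the compounds shown alone.

Measured compounds:
compound 1, `COc1ccc(-c2nc3ccccn3c2/C=C/C(=O)c2cc(OC)c(OC)c(OC)c2)cc1`, 5220 nM
compound 2, `COc1cc(C(=O)/C=C/c2c(-c3ccc(F)cc3)nc3ncccn23)cc(OC)c1OC`, 2990 nM

Both compounds were tested in a functional assay on MDA-MB-231 cells (Homo sapiens) for inhibition, read by sulforhodamine B assay, with a stated time of 48 h; a lower number here means a stronger inhibitor of growth, a higher number a weaker inhibitor of growth. Compound 1 gives 5220 nM in this assay, and compound 2 gives 2990 nM. Compound 2 carries the lower of the two numbers, but the gap between them lies within the usual scatter of repeated measurements, so the two cannot be told apart on these data.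

Compound 3, `COc1ccc(-c2nc3ncccn3c2/C=C/C(=O)c2cc(OC)c(OC)c(OC)c2)cc1`, has not yet been measured in this assay. It differs from compound 2 in one place: methoxy in place of fluoro on an aromatic carbon. Put another way, a 4-fluorophenyl becomes a 4-methoxyphenyl, the group that compound 1 already carries on its own, slightly different, core.

Within the data shown here, no step between two measured compounds shows what this change does on its own. With compound 1 at 5220 nM and compound 2 at 2990 nM sitting within the scatter of each other, the expectation for compound 3 is a step of a 1.3-fold higher number from compound 2 to compound 3 (0.13 log units; within the scatter), small and not beyond the scatter. Compound 3 is therefore estimated at 4000 nM, with a range from 1500 nM to 11000 nM.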

Compound 3, concentration for 50% growth inhibition: 2730 nM
For compound 3 the middle estimate is 1.5-fold (0.17 log units) above the measured one; low and high end bracket the measured number.
By their numbers in this assay, from the lowest: compounds 3, 2 and 1 (each within the scatter of the next).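

On the core shared by compound 2 and compound 3, the swap from 4-fluorophenyl to 4-methoxyphenyl can now be read directly: this assay gives a 1.1-fold lower number from compound 2 to compound 3 (0.04 log units; within the scatter) for this one change. At this place, on an aromatic carbon para to a large group, fluoro and methoxy cannot be told apart in this growth read-out, even though methoxy brings one more heavy atom and a hydrogen-bond acceptor by the count used here. Nothing in the data shown explains this result.

The comparison covers only these two groups at one position, so it does not show that the position accepts any group equally: an amine, a carboxylic acid or a longer chain such as butoxy could give a very different number here. From the compounds shown here alone, whether the same swap reads the same way on the core of compound 1 also stays open, and so does whether a similar result would appear in cells other than those tested here.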